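The source may hold more compounds than are shown below. What is called first, only, known or untested is meant among the compounds shown, and "the series" means these compounds.

Compound 1 `O=C(N/N=C/c1ccccc1O)c1cc(-c2ccccc2)nn1Cc1ccccc1` gives 44000 nM in a functional assay on A549 cells (Homo sapiens) for cytotoxicity, read by MTT assay, with a stated time of 48 h; a lower number here means a less soluble compound, a higher number a more soluble compound. Compound 2 `CC(C)(C)c1ccc(Cn2nc(-c3ccccc3)cc2C(=O)N/N=C/c2ccccc2O)cc1` carries tert-butyl in place of hydrogen on an aromatic carbon and gives 47000 nM in this assay, the step being a 1.1-fold higher number from compound 1 to compound 2 (0.03 log units; within the scatter). Compound 3 `O=C(N/N=C/c1ccccc1O)c1cc(-c2ccc(Cl)cc2)nn1Cc1ccccc1` differs from compound 1 by chloro in place of hydrogen on an aromatic carbon; in this assay compound 3 gives 25000 nM, the step being a 1.8-fold lower number from compound 1 to compound 3 (0.25 log units; within the scatter). Compound 4 `CC(C)(C)c1ccc(Cn2nc(-c3ccc(Cl)cc3)cc2C(=O)N/N=C/c2ccccc2O)cc1`, not yet measured, differs from compound 3 by tert-butyl in place of hydrogen on an aromatic carbon. This is the same change as that between compound 1 and compound 2, at a place described in the same words, and it occurs twice in the set. For the measured compounds named here, the step from compound 3 to compound 4 is expected to be a 1.1-fold higher number from compound 3 to compound 4 (0.03 log units; within the scatter) in this assay, resting on the one earlier instance, a 1.1-fold higher number from compound 1 to compound 2 (0.03 log units; within the scatter). Compound 4 is therefore estimated at 27000 nM, with a likely range from 14000 nM to 52000 nM.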

Compound 4, solubility: 36000 nM
Compound 4: the middle estimate sits 1.3-fold (0.12 log units) below what was measured, and the stated range covers the measured number.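

In this assay, tert-butyl in place of hydrogen on an aromatic carbon gives a 1.4-fold higher number from compound 3 to compound 4 (0.16 log units; within the scatter), and the step carries from one core to the other with no difference beyond the scatter: the same change on two cores in this assay, a 1.1-fold higher number (0.03 log units; within the scatter) from compound 1 to compound 2 and a 1.4-fold higher number (0.16 log units; within the scatter) from compound 3 to compound 4, 1.3-fold (0.13 log units) apart, within the scatter of two such steps. Chloro in place of hydrogen on an aromatic carbon, here a 1.3-fold lower number from compound 2 to compound 4 (0.12 log units; within the scatter), likewise carries over: the same change on two cores in this assay, a 1.8-fold lower number (0.25 log units; within the scatter) from compound 1 to compound 3 and a 1.3-fold lower number (0.12 log units; within the scatter) from compound 2 to compound 4, 1.3-fold (0.13 log units) apart, within the scatter of two such steps. All four steps lie within the scatter, so the series shows that neither change depends measurably on the core in these compounds, but it does not show that either change moves the number at all, and two cores say nothing of others.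

Still open, going by these compounds, is whether an amine or a carboxylic acid in place of the tert-butyl or the chloro would give a step beyond the scatter, and whether such a step would carry between cores.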